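The source may hold more compounds than are shown below. What is called first, only, known or untested is meant among the compounds shown, and "the series" means these compounds.

Measured so far in a functional assay on MCF7 cells (Homo sapiens) for inhibition, read by MTT assay, with a stated time of 48 h, tested at 10 uM; a lower number here means less inhibition of growth, a higher number more inhibition of growth at the concentration tested 
- compound 1 `Cc1oc2c([C@H]3CCN(C)C[C@H]3O)c(O)cc(O)c2c(=O)c1C(O)c1cccc(Cl)c1` gives 5% 
- compound 2 `Cc1oc2c([C@H]3CCN(C)C[C@H]3O)c(O)cc(O)c2c(=O)c1C(O)c1ccccc1Br` gives 21%

Compound 2 stands highest of the two at 21% and compound 1 lies lower, beyond the scatter. Compound 3 `Cc1oc2c([C@H]3CCN(C)C[C@H]3O)c(O)cc(O)c2c(=O)c1C(O)c1c(Cl)cccc1Cl` differs from compound 2 by 2,6-dichlorophenyl in place of 2-bromophenyl on a saturated chain carbon bound to an aromatic carbon and an oxygen on a saturated carbon on a saturated chain carbon bound to an aromatic carbon and an oxygen on a saturated carbon. Within the data shown here, the one measured step at this place is a number 16 percentage points higher from compound 1 to compound 2 (beyond the scatter) and it is modest. A step of that size or smaller is expected in this assay with no clear direction. The expected change is a number 3 percentage points lower from compound 2 to compound 3 (within the scatter) and no more. For compound 3 the estimate is 18% with an expected range from 3% to 38% as the likely span.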

Compound 3, percent growth inhibition at one concentration: 33%
Compound 3: middle estimate off by 15 percentage points, on the low side, and the stated range covers the measured number.
By their numbers in this assay, from the lowest: compound 1; then compound 2; then compound 3.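

At the saturated chain carbon bound to an aromatic carbon and an oxygen on a saturated carbon, this assay again responds to the aryl group: 2,6-dichlorophenyl gives a number 12 percentage points higher from compound 2 to compound 3 (beyond the scatter) and, against 3-chlorophenyl, a number 28 percentage points higher from compound 1 to compound 3 (beyond the scatter). Compound 3 therefore stands highest of the three, and a phenyl group carrying two chlorines is compatible with this place. No measurement here bears on the reason for this rise.

Open, going by these compounds, is how unsubstituted phenyl or a phenyl carrying an amine or a carboxylic acid would read at this place. On these data alone, the effect of replacing the hydroxy on this carbon with a methoxy group also remains open.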